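The source may hold more compounds than are shown below. What is called first, only, known or untested is meant among the compounds shown, and "the series" means these compounds.

Measured so far:
Compound 1 `CCN(CC)c1ccc2cc(C(=O)c3ccc(N4CCN(C(=O)CN5CCN(C(=O)CCl)CC5)CC4)cc3)oc2c1`: in a functional assay on MCF7 cells (Homo sapiens) for cytotoxicity, read by MTT assay, with a stated time of 48 h (on this read-out higher numbers stand for weaker inhibition and lower numbers for stronger inhibition), compound 1 gives > 40000 nM, which is a limit of the assay and not a number.
Compound 2 `CCN(CC)c1ccc2cc(C(=O)c3ccc(N4CCN(C(=O)CN5CCN(S(=O)(=O)c6ccc(C#N)cc6)CC5)CC4)cc3)oc2c1`: in this assay compound 2 gives > 40000 nM, likewise a limit rather than a number.

Compound 2 thus stands at the limit of > 40000 nM in this assay, at which 2 of the 2 values shown sit. The step that the two limits leave unreadable from compound 1 to compound 2 cannot be read, since both of its ends are limits. Compound 3 `C#CCN1CCN(CC(=O)N2CCN(c3ccc(C(=O)c4cc5ccc(N(CC)CC)cc5o4)cc3)CC2)CC1` differs from compound 2 in one place: propargyl in place of (4-cyanophenyl)sulfonyl on an amine nitrogen in a ring. No measured step resembles this change, and the single step shown has no readable size, so there is no basis for expecting a shift in either direction in this assay beyond the scatter. Compound 3 is therefore expected to give 40000 nM in this assay, in a range of 10000 nM to 100000 nM, most likely again reported only as a limit. Among the measured compounds shown here, that expectation amounts to a step of a number no higher from compound 2 to compound 3 (the limit leaves the size open), estimated as no step at all.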

Compound 3, half-maximal inhibitory concentration: > 40000 nM
Compound 3: only a limit was reported (the forecaster's own chance of this, stated with the estimate: 75%); the middle value sits exactly at the limit.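

No step among compound 1, compound 2 and compound 3 can be read, since each result is a limit and not a number: the limit of > 40000 nM in this assay, at which 3 of the 3 values shown sit.

The compounds shown leave open how far each one lies past that limit, and whether changing the group on the amine nitrogen in a ring alters the result in this assay at all.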